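A few compounds are considered here, and "the series" means these few. Any claim that something is new, unique, unknown or untested is made for them only; others in the source may bear on it.

Measured compounds:
compound 1, `CSc1nnc(Cc2ccc(Cl)cc2Oc2ccccc2Cl)[nH]1`, 170%
compound 2, `CSc1nnc(Cc2ccc(Cl)cc2Oc2ccccc2F)[nH]1`, 136%

In a functional assay on the whole organism (strain NMRI) with Mus musculus as the target, with a stated time of 60 min, at a dose of 20 mg/kg by the intraperitoneal route (on this read-out higher numbers stand for a stronger effect at the one dose given and lower numbers for a weaker effect), compound 2 stands lowest of the two numbers; its nearest neighbour is compound 1, whose number lies a number 34 percentage points lower from compound 1 to compound 2 (beyond the scatter). That single step, from compound 1 to compound 2, rests on a fluoro in place of chloro on an aromatic carbon.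

Compound 3, `Nc1nnc(Cc2ccc(Cl)cc2Oc2ccccc2F)o1`, has not yet been tested in this assay. It differs from compound 2 by a group of 6 heavy atoms (2 carbon, 3 nitrogen, 1 oxygen; one five-membered aromatic ring with 3 hetero atoms) in place of a group of 7 heavy atoms (3 carbon, 3 nitrogen, 1 sulfur; one five-membered aromatic ring with 3 hetero atoms), on a saturated chain carbon bound to an aromatic carbon. For the measured compounds named here, the one measured step concerns a different part of the molecule, an exchange of a halogen on an aromatic ring, and so does not bear on the exchange of one five-membered aromatic ring for another on the saturated chain carbon. Going by the values given here, no measured pair shows what such a change does in this assay. Because compound 2 gives 136%, the expectation for compound 3 can only be anchored to that number, with a wide range in both directions. Compound 3 is therefore estimated at 125%, between 60% and 190%. This estimate corresponds to an expected step of a number 11 percentage points lower from compound 2 to compound 3 (beyond the scatter), with no direction claimed beyond the scatter.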

Compound 3, a percentage reported as activity, at one dose (the size of the read-out at that dose, not a potency): 154%
Compound 3: middle estimate off by 29 percentage points, on the low side; the range from low to high includes it.
By their numbers in this assay, from the lowest: compound 2; then compound 3; then compound 1.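

For the compounds shown here, with compound 3, the saturated chain carbon bound to an aromatic carbon appears for the first time as a place that also moves the read-out, which the halogen exchange on the aromatic ring could not show. In this assay, putting the 5-amino-1,3,4-oxadiazol-2-yl group in place of the group of 7 heavy atoms gives a number 18 percentage points higher from compound 2 to compound 3 (beyond the scatter), so this five-membered aromatic ring with 3 hetero atoms can be exchanged for another without loss of the effect at the one dose given, and the number in fact rises by a step beyond the scatter. Nothing at hand explains why this exchange raises the number.

On these data alone, the pair changes the ring and its substituent together, so it remains open which of the two carries the step, and whether a methyl group or an acetamide in place of the amine of the 5-amino-1,3,4-oxadiazol-2-yl group would keep the effect. As far as these compounds go, it is equally open whether chloro in place of fluoro on the aromatic carbon would act on this group as it does in the earlier pair, or what a carboxylic acid or a longer chain would do on the saturated chain carbon.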